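Chloro Added to the Bromoacrylamide Analogue in HeLa Cells

A few compounds are considered here, and "the series" means these few. Any claim that something is new, unique, unknown or untested is made for them only; others in the source may bear on it.

Measured so far:
Compound 1, `Nc1cccc(-c2cn3c(-c4ccc(Cl)cc4)csc3n2)c1`, in a functional assay on HeLa cells (Homo sapiens) for inhibition, read by cell counting, with a stated time of 4 days (a higher number here means a weaker inhibitor, a lower number a stronger inhibitor), compound 1 gives 17000 nM.
Compound 2, `Nc1cccc(-c2cn3c(-c4ccccc4)csc3n2)c1`, in this assay compound 2 gives 60000 nM.
Compound 3, `C=C(Br)C(=O)Nc1cccc(-c2cn3c(-c4ccccc4)csc3n2)c1`, in this assay compound 3 gives 3400 nM.

Compounds 1 and 2 share the same core and differ in one place only: chloro in place of hydrogen on an aromatic carbon. That single change produced a 3.5-fold lower number from compound 2 to compound 1 (0.55 log units; beyond the scatter). Compound 3 differs from compound 2 at a different place, on the nitrogen rather than on the ring: (1-bromoethenyl)carbonyl in place of hydrogen on a nitrogen on an aromatic ring. That change produced an 18-fold lower number from compound 2 to compound 3 (1.25 log units; beyond the scatter), and compound 3 holds the lowest number of the three measured compounds, its steps to both others lying beyond the scatter.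

Compound 4, `C=C(Br)C(=O)Nc1cccc(-c2cn3c(-c4ccc(Cl)cc4)csc3n2)c1`, has not yet been measured. It differs from compound 3 by chloro in place of hydrogen on an aromatic carbon. For the measured compounds named here, this is the same change, at the same kind of place, as the one from compound 2 to compound 1; the two cores carrying it differ only in the way described for compound 3 against compound 2.

Going by the values given here, the step from compound 3 to compound 4 in this assay is expected to be a 3.4-fold lower number from compound 3 to compound 4 (0.53 log units; beyond the scatter), about the size of the earlier step, because a 3.5-fold lower number from compound 2 to compound 1 (0.55 log units; beyond the scatter) is the only measured example of this change. With one example, the expectation rests on a single step and is held loosely. Compound 4 is estimated at 1000 nM, expected to fall between 400 nM and 3000 nM.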

Compound 4, half-maximal inhibitory concentration: 3000 nM
Compound 4: the middle estimate sits 3.0-fold (0.48 log units) below what was measured; low and high end bracket the measured number.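

On the core carrying the (1-bromoethenyl)carbonyl group, the change from phenyl to 4-chlorophenyl gave a 1.1-fold lower number from compound 3 to compound 4 (0.05 log units; within the scatter) in this assay, so the step seen on the amine core did not carry over at its earlier size: the same change on two cores in this assay, a 3.5-fold lower number (0.55 log units; beyond the scatter) from compound 2 to compound 1 and a 1.1-fold lower number (0.05 log units; within the scatter) from compound 3 to compound 4, 3.1-fold (0.49 log units) apart, beyond the scatter of two such steps

Read the other way round, the same four compounds show that adding the (1-bromoethenyl)carbonyl group to the amine nitrogen gave a 5.7-fold lower number from compound 1 to compound 4 (0.75 log units; beyond the scatter) on the chloro-bearing core, a step still beyond the scatter but not the same as the one on the core without chloro: the same change on two cores in this assay, an 18-fold lower number (1.25 log units; beyond the scatter) from compound 2 to compound 3 and a 5.7-fold lower number (0.75 log units; beyond the scatter) from compound 1 to compound 4, 3.1-fold (0.49 log units) apart, beyond the scatter of two such steps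

So in this small set the effects of the two changes do not simply add up, but one pair of cores cannot show why this happens or whether it would also happen on other cores in the series.

As far as these compounds go, it remains open whether another group at the same place, such as fluoro, methyl or methoxy, would follow chloro in having a step that depends on the core. From the compounds shown here alone, it is also open whether the dependence needs the bromine, which a plain acryloyl or acetyl group on the nitrogen could help to test.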